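The compounds below may be only part of what the source reports. "The series", "measured", "known", "first", "only" and "open" are said of these compounds alone.

Measured so far in a physicochemical assay for solubility, measured as kinetic solubility; a lower number here means a less soluble compound, a higher number a more soluble compound:
- Compound 1 `O=C(Nc1ccnnc1)c1cc(C(F)(F)F)ccc1OCc1ccccc1`: < 1000 nM, a limit of the assay and not a number.
- Compound 2 `C[C@@H]1CN(c2ccc(OCc3ccccc3)c(C(=O)Nc3ccnnc3)c2)C[C@H](C)O1`: 29000 nM.

Going by the values given here, compound 2 holds the only true number, 29000 nM, so there is no other number to rank it against.

Compound 3 `CN1CCN(c2ccc(OCc3ccccc3)c(C(=O)Nc3ccnnc3)c2)CC1` carries 4-methylpiperazin-1-yl in place of the 2,6-dimethylmorpholin-4-yl of compound 2, on an aromatic carbon para to a benzyloxy group and meta to a (pyridazin-4-yl)carbamoyl group: 4-methylpiperazin-1-yl in place of 2,6-dimethylmorpholin-4-yl on an aromatic carbon.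

Among the compounds with values here, one measured step bears on this place: an at least 29-fold higher number from compound 1 to compound 2 (1.46 log units; beyond the scatter), large and beyond the scatter, with 2,6-dimethylmorpholin-4-yl replacing trifluoromethyl. The new change instead exchanges one six-membered non-aromatic ring for another. Within the data shown here, with an at least 29-fold higher number from compound 1 to compound 2 (1.46 log units; beyond the scatter) as the only guide, a much smaller step is expected in this assay, leaning weakly towards a higher number and not expected to clear the scatter. The expected change is a 1.7-fold higher number from compound 2 to compound 3 (0.24 log units; within the scatter). Compound 3 is estimated at 50000 nM, with an expected range of 15000 nM to 150000 nM.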

Compound 3, solubility: 228000 nM
The estimate for compound 3 lay 4.6-fold (0.66 log units) below the measured number; the measured number lies above the stated range.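

In this assay, the identity of the ring on this aromatic carbon, para to a benzyloxy group, matters and not only the removal of trifluoromethyl: exchanging one six-membered non-aromatic ring for another gives a 7.9-fold higher number from compound 2 to compound 3 (0.90 log units; beyond the scatter). Measured against the trifluoromethyl starting point, 4-methylpiperazin-1-yl gives an at least 220-fold higher number from compound 1 to compound 3 (2.35 log units; beyond the scatter), which widens the gain seen with 2,6-dimethylmorpholin-4-yl. That wider gain is a bound and not a measured size, and compound 1 stands at a limit of the assay and not a number: the limit of < 1000 nM in this assay, at which 1 of the 3 values shown sits.

The step from compound 2 to compound 3 changes several things at once (the ring oxygen, the ring nitrogen with its methyl, and the defined stereocentres), and the compounds shown do not separate these contributions. Open as well is how plain morpholin-4-yl, with no ring methyl groups, or piperazin-1-yl, with a free ring amine, would read at this position in this assay, and so whether the higher number follows the second ring nitrogen or the loss of the substituted morpholine.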